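Kinetic solubility notes: hydrazide replacing cyclopentyl ketone

This account rests on a few compounds, and the source may have more. Where it says the series, first, only, none or still open, it means among the compounds named here.

Measured so far:
compound 1 `CCC(=O)c1cc(-c2ccc(Cl)cc2)n(-c2ccc(S(C)(=O)=O)cc2)c1C`; in a physicochemical assay for solubility, read by HPLC, in phosphate buffer, measured as kinetic solubility, at pH 7.4 (a lower number here means a less soluble compound, a higher number a more soluble compound), compound 1 gives 4800 nM
compound 2 `CCC(=O)c1cc(-c2ccc(OC)cc2)n(-c2ccc(S(N)(=O)=O)cc2)c1C`; in this assay compound 2 gives 12800 nM
compound 3 `NS(=O)(=O)c1ccc(-c2cc(C(=O)C3CCCC3)nn2-c2ccc(Cl)cc2)cc1`; in this assay compound 3 gives 4600 nM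

Compound 3 sits at the low end of the three numbers. Its gap to compound 1 lies within the scatter of repeated measurements, so no order between those two is claimed; its gap to compound 2 lies beyond the scatter, compound 2 standing higher.

Compound 4 `NS(=O)(=O)c1ccc(-c2cc(C(=O)NN3CCCCC3)nn2-c2ccc(Cl)cc2)cc1` is not yet measured. It differs from compound 3 in one place: (piperidin-1-yl)amino in place of cyclopentyl on a carbonyl carbon. For the measured compounds named here, no measured pair shows this change, so the expectation rests on compound 3 alone. A modest step upward is expected, a 2.0-fold higher number from compound 3 to compound 4 (0.29 log units; within the scatter), close to the edge of the scatter. Compound 4 is estimated at 9000 nM, with a range from 3500 nM to 25000 nM.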

Compound 4, solubility: 53700 nM
Beside the measured number, compound 4's estimate is 6.0-fold (0.78 log units) below it; measured number outside the range, above it.
By their numbers in this assay, from the lowest: compounds 3 and 1 (each within the scatter of the next); then compound 2; then compound 4.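

Reading this assay, putting (piperidin-1-yl)amino in place of cyclopentyl on a carbonyl carbon gives a 12-fold higher number from compound 3 to compound 4 (1.07 log units; beyond the scatter) and is the first single-place step available in the series. This position can therefore carry a large change in the read-out, well beyond the scatter. No measurement on hand accounts for the step.

The compounds shown do not separate the ring change from the added nitrogens, and a cyclohexylamino group on the same carbonyl carbon would bear on that. As far as these compounds go, whether the same replacement behaves alike on other cores also stays open.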